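The source may report more compounds than this note shows. Statements on the series, on what has been measured and on what is new or still open speak of the compounds shown alone.

Compound 1 `O=S(=O)(Nc1cc(-c2cnc3[nH]ncc3c2)cnc1Cl)c1ccccc1`: 1090 nM
Compound 2 `O=S(=O)(Nc1cc(-c2cnc3[nH]nc(-c4ccccc4)c3c2)cnc1Cl)c1ccccc1`: 1230 nM

In a functional assay on KARPAS-422 cells (Homo sapiens) for inhibition, read by CCK-8 assay (on this read-out lower numbers stand for stronger inhibition of growth and higher numbers for weaker inhibition of growth), compound 1 gives 1090 nM and compound 2 gives 1230 nM. The step of a 1.1-fold higher number from compound 1 to compound 2 (0.05 log units; within the scatter) lies within the scatter, so the two values show no difference. Compound 2 thus stands level with compound 1; no ordering between them is supported.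

Compound 3 `O=S(=O)(Nc1cc(-c2cnc3[nH]nc(-c4ccncc4)c3c2)cnc1Cl)c1ccccc1` differs from compound 2 by pyridin-4-yl in place of phenyl on an aromatic carbon. Among the measured compounds shown here, the only measured step, a 1.1-fold higher number from compound 1 to compound 2 (0.05 log units; within the scatter), bears on this position: it shows that putting a six-membered aromatic ring there left the growth-inhibition number unchanged within the scatter. For the measured compounds named here, no measured step shows what exchanging one ring for another of the same size at this position does, so no direction beyond the scatter can be drawn from the data. The expectation for compound 3 in this assay is therefore a number close to that of compound 2, with a 1.1-fold lower number from compound 2 to compound 3 (0.05 log units; within the scatter) expected to stay within the scatter. Compound 3 is estimated at 1100 nM (range 400 nM to 3000 nM).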

Compound 3, concentration for 50% growth inhibition: 170 nM
Beside the measured number, compound 3's estimate is 6.5-fold (0.81 log units) above it, outside the stated range (below it).
By their numbers in this assay, from the lowest: compound 3; then compounds 1 and 2 (each within the scatter of the next).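

In this assay, this aromatic carbon of the five-membered ring responds to which six-membered aromatic ring it carries: exchanging phenyl for pyridin-4-yl, one ring carbon for one ring nitrogen at the same heavy-atom count, gives a 7.2-fold lower number from compound 2 to compound 3 (0.86 log units; beyond the scatter). Phenyl had shown no difference from hydrogen here, whereas pyridin-4-yl stands clearly apart from hydrogen, with a 6.4-fold lower number from compound 1 to compound 3 (0.81 log units; beyond the scatter), so the position does tolerate a ring and can also yield a gain in growth inhibition. No measurement on hand accounts for this gain.

Still open, as far as these compounds go, is whether the gain depends on where the nitrogen sits in the ring, a question pyridin-3-yl or pyridin-2-yl would address. Also open, from the compounds shown here alone, is whether a ring is needed at all, which a morpholine or a dimethylamino group on the same carbon would test.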